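Triazolopyridine series: amine substituent change at compound 2

This account rests on a few compounds, and the source may have more. Where it says the series, first, only, none or still open, it means among the compounds named here.

Measured so far:
compound 1 `CCOCc1nnc2c(C(F)(F)F)c(-c3ccc(Oc4ccc(C)nc4C)c(F)c3)ccn12` — 11.8 nM
compound 2 `CC(C)Nc1ccc(-c2ccn3c(CC4CC4)nnc3c2C(F)(F)F)cc1Cl` — 3.89 nM
compound 3 `COc1ccc(COc2ccc(-c3ccn4c(CC5CC5)nnc4c3C(F)(F)F)cc2F)cn1` — 11.8 nM

In an assay on cells for displacement of a labelled ligand from metabotropic glutamate receptor 2 (Homo sapiens), read by scintillation counting, with a stated time of 60 min (a higher number here means a weaker inhibitor, a lower number a stronger inhibitor), compound 2 gives the lowest of the three numbers. Compound 1 gives a number that is higher, and the gap lies beyond the scatter. Compound 3 gives a number that is also higher, again by a gap beyond the scatter. Compound 2 is therefore the strongest inhibitor among the three on these figures.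

The next compound, compound 4 `O[C@]1(C2CC2)CC[C@H](Nc2ccc(-c3ccn4c(CC5CC5)nnc4c3C(F)(F)F)cc2Cl)CC1`, keeps the shared core and the chloro-substituted ring of compound 2 and alters only the group on the nitrogen: 4-cyclopropyl-4-hydroxycyclohexyl in place of isopropyl on a nitrogen on an aromatic ring. For the measured compounds named here, no step between two measured compounds shows what such a change does here, so the direction rests on judgement alone. The expectation is a step from compound 2 to compound 4 of a 1.1-fold lower number from compound 2 to compound 4 (0.05 log units; within the scatter), which is no move beyond the scatter. Compound 4 is estimated at 3.5 nM in this assay, with a range from 1.2 nM to 12 nM.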

Compound 4, inhibition constant: 0.891 nM
Beside the measured number, compound 4's estimate is 3.9-fold (0.59 log units) above it; measured number outside the range, below it.
By their numbers in this assay, from the lowest: compound 4; then compound 2; then compounds 1 and 3 (each within the scatter of the next).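

On a nitrogen on an aromatic ring, the substituent can grow well beyond isopropyl without loss: in this assay the change to 4-cyclopropyl-4-hydroxycyclohexyl gives a 4.4-fold lower number from compound 2 to compound 4 (0.64 log units; beyond the scatter) and this step lies beyond the scatter. For the compounds shown here, the single step brings in more heavy atoms, two rings, a hydrogen-bond donor, a hydrogen-bond acceptor and 2 defined stereocentres all at once, so it cannot assign the lower number to any one of these features. No measurement shown bears on why the number falls.

Open, from the compounds shown here alone, is whether a plain cyclohexyl or a 4-hydroxycyclohexyl without the cyclopropyl would keep the lower number, which would show how much the hydroxyl and the cyclopropyl each contribute. Also open, going by these compounds, is how the other stereoisomer of the 4-cyclopropyl-4-hydroxycyclohexyl group compares.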